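Allyloxy for 1,3-dimethyl-1H-pyrazol-5-yl on a carbonyl carbon

The source may hold more compounds than are shown below. What is called first, only, known or untested is meant among the compounds shown, and "the series" means these compounds.

Among the measured compounds shown here, in a functional assay on WI-38 VA13 cells (Homo sapiens) for cytotoxicity (a lower number here means that less compound is needed, a higher number that more compound is needed for the effect), compound 1 `O=C(Nc1ccc2nc(NC(=O)C3CCCCC3)sc2c1)c1ccccc1F` gives 0.14 ug/mL and compound 2 `Cc1cc(C(=O)Nc2ccc3nc(NC(=O)C4CCCCC4)sc3c2)n(C)n1` gives 0.12 ug/mL so compound 2 stands within the scatter of its only measured neighbour. For the measured compounds named here, the one measured step (a 1.2-fold lower number from compound 1 to compound 2 (0.07 log units; within the scatter)) puts 1,3-dimethyl-1H-pyrazol-5-yl in place of 2-fluorophenyl on a carbonyl carbon, and it lies within the scatter.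

Compound 3 `C=CCOC(=O)Nc1ccc2nc(NC(=O)C3CCCCC3)sc2c1` is still unmeasured. It carries allyloxy in place of 1,3-dimethyl-1H-pyrazol-5-yl on a carbonyl carbon. The measured step exchanged one ring-bearing group for another, whereas here a ring leaves and none enters, so that step bears on this change only loosely. Going by the values given here, no measured compound has a group without a ring at this place, and the direction of any shift remains poorly supported. A small move toward a higher number is expected, not clearly beyond the scatter (expected: a 1.7-fold higher number from compound 2 to compound 3 (0.22 log units; within the scatter)). For compound 3 the estimated value is 0.2 ug/mL (expected range 0.06 ug/mL to 0.8 ug/mL).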

Compound 3, half-maximal effective concentration: 0.58 ug/mL
Estimate against measurement, compound 3: 2.9-fold (0.46 log units) below; measured number inside the range.
By their numbers in this assay, from the lowest: compounds 2 and 1 (each within the scatter of the next); then compound 3.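

In this assay, the position on the carbonyl carbon proves not to be indifferent to the group it carries: allyloxy in place of 1,3-dimethyl-1H-pyrazol-5-yl gives a 4.8-fold higher number from compound 2 to compound 3 (0.68 log units; beyond the scatter), and allyloxy in place of 2-fluorophenyl gives a 4.1-fold higher number from compound 1 to compound 3 (0.62 log units; beyond the scatter). The earlier exchange of one ring-bearing group for another stayed within the scatter, whereas both steps to the ringless allyloxy group lie beyond it and run in the same direction, towards more compound being needed for the effect. No measured data on the compounds are available to explain this shift.

Allyloxy differs from both ring-bearing groups in several ways at once, including the loss of the ring, fewer heavy atoms, an oxygen on the carbonyl carbon and a double bond outside aromatic rings, so the compounds shown leave open which of these differences goes with the higher number. Phenoxy would keep a ring with an oxygen on the carbonyl carbon, while propyl would have neither a ring nor that oxygen, and propoxy would differ from allyloxy only in lacking the double bond.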